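The source may report more compounds than this note shows. Statements on the series, on what has been measured and on what is new or still open speak of the compounds shown alone.

Measured in a functional assay on DU-145 cells (Homo sapiens) for cytotoxicity, read by trypan blue exclusion, with a stated time of 96 h; a higher number here means a weaker inhibitor, a lower number a stronger inhibitor:
- compound 1 `COc1cc(OC)c(/C=C/S(=O)(=O)Cc2ccc(OC)c([N+](=O)[O-])c2)c(OC)c1`: 2500 nM
- compound 2 `COc1ccc(CS(=O)(=O)/C=C/c2c(OC)cc(OC)cc2OC)c(N)c1`: 25 nM
- compound 3 `COc1cc(OC)c(/C=C/S(=O)(=O)Cc2ccc(OC)c(N)c2)c(OC)c1`: 4 nM

Among these three, compound 3 has the lowest number, 4 nM, and its steps to the other two both lie beyond the scatter. The next compound to consider is compound 4 `COc1cc(OC)c(/C=C/S(=O)(=O)Cc2ccc(Br)c(N)c2)c(OC)c1`, which has not yet been measured. It keeps the shared core and changes one group: bromo in place of methoxy on an aromatic carbon.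

Within the data shown here, no measured step replaces this methoxy group, so the data give no direct size for the change. Two steps do alter the same 3-amino-4-methoxyphenyl group. The first, a 630-fold lower number from compound 1 to compound 3 (2.80 log units; beyond the scatter), is large and swaps nitro for amino. The second, a 6.3-fold lower number from compound 2 to compound 3 (0.80 log units; beyond the scatter), is modest and involves 2-amino-4-methoxyphenyl. Both show that changes to this part of the molecule can move the number well beyond the scatter, and each of them leaves a higher number on the side away from compound 3 at 4 nM. A modest rise is therefore the more likely outcome, though this remains uncertain.

The expected change is a 6.3-fold higher number from compound 3 to compound 4 (0.80 log units; beyond the scatter). Compound 4 is estimated at 25 nM, with an expected range of 5 nM to 150 nM.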

Compound 4, half-maximal inhibitory concentration: 750 nM
Compound 4: middle estimate off by 30-fold (1.48 log units), on the low side, and the stated range ends below it.
By their numbers in this assay, from the lowest: compound 3; then compound 2; then compound 4; then compound 1.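

In this assay the amino group stays where it is and only the group ortho to it changes, from methoxy to bromo, giving a 190-fold higher number from compound 3 to compound 4 (2.27 log units; beyond the scatter). Among these compounds, this is the first direct reading of this position, and it shows that the methoxy group matters in its own right: the earlier steps changed the amino group or its place on the ring, and neither touched the methoxy group. Compound 2, with its amino group elsewhere but its methoxy group kept, also stands well below the new compound, with a 30-fold higher number from compound 2 to compound 4 (1.48 log units; beyond the scatter), a large step, whereas the step between compound 2 and compound 3 is only modest. Nothing available here explains why the number rises so far.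

The compounds shown carry only methoxy or bromo at this place, so how an ethoxy, a hydroxy or a chloro group there would read remains open. They also cannot separate the effect of bringing in bromo from that of removing methoxy, a question that a plain hydrogen at this place could help to answer.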